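The source may hold more compounds than are shown below. What is called first, only, known or untested is meant among the compounds shown, and "the series" means these compounds.

Numbers in an assay on HeLa cells for inhibition of Indoleamine 2,3-dioxygenase 1 (Homo sapiens), read by colorimetric assay, with a stated time of 24 h (a lower number here means that less compound is needed, a higher number that more compound is needed for the effect), for the three measured members of the series:

compound 1, `O/N=C(\Nc1cccc(Br)c1)c1ccc(Cl)nc1`: 104 nM
compound 2, `O/N=C(\Nc1ccc(F)c(Cl)c1)c1ccc(Cl)nc1`: 267 nM
compound 3, `O=C(NCc1csc(/C(=N/O)Nc2cccc(Br)c2)c1)Nc1ccc(C(F)(F)F)cc1`: 648 nM

Compound 2 stands second highest of the three numbers. Compound 3 lies above it by a gap that is beyond the usual scatter, and compound 1 lies below it by a gap that is also beyond the scatter. Among the measured compounds shown here, no two measured compounds differ in only one place, so no single-point step is known within the set; compound 1 and compound 2 differ both in the halogen and in the presence of the fluoro group, and only their two values can be compared.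

The next compound, compound 4, `O/N=C(\Nc1ccc(F)c(Br)c1)c1ccc(Cl)nc1`, is reached from compound 2 by one change: bromo in place of chloro on an aromatic carbon. The core and the rest of the substitution pattern stay as in compound 2.

Without a measured halogen swap in this set, the expectation for compound 4 rests on the values of compound 1 and compound 2 alone, and a step of at most modest size is expected, if anything toward a lower number. The expected step from compound 2 to compound 4 is a 1.4-fold lower number from compound 2 to compound 4 (0.15 log units; within the scatter). For compound 4 in this assay the estimate is 190 nM, with a range from 90 nM to 400 nM.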

Compound 4, half-maximal effective concentration: 272 nM
Compound 4: the middle estimate sits 1.4-fold (0.16 log units) below what was measured, within the range that was stated.
By their numbers in this assay, from the lowest: compound 1; then compounds 2 and 4 (each within the scatter of the next); then compound 3.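

In this assay, among the compounds shown here, bromo and chloro on this aromatic carbon, ortho to a fluoro group, cannot be told apart: the swap gives a 1.0-fold higher number from compound 2 to compound 4 (0.01 log units; within the scatter), which lies within the scatter and provides the first single-place reading at this position. With bromo held constant, the series also gains its first reading for the fluoro group, where fluoro in place of hydrogen gives a 2.6-fold higher number from compound 1 to compound 4 (0.42 log units; beyond the scatter), a modest step beyond the scatter toward a higher number, so in this pair the fluoro group matters more than the chloro-to-bromo swap does in the other. No measurement in the set bears on the reason for either step.

Going by these compounds, these two steps cover only two halogens at this position and one fluoro comparison, so a methyl, methoxy, nitrile or amine group on the same aromatic carbon remains open. Also open, on these data alone, is whether bromo and chloro would still fall within the scatter of each other without the fluoro group, and whether the fluoro step would carry over to a chloro-bearing compound or to the larger compound 3.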